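Trading an acetyl for hydrogen on a tricyclic ester core

The source may report more compounds than this note shows. Statements on the series, on what has been measured and on what is new or still open speak of the compounds shown alone.

Of the compounds shown here, two sharing one core have been measured in a functional assay on RS4-11 cells (Homo sapiens) for cytotoxicity, read by MTT assay, with a stated time of 72 h; on this read-out higher numbers stand for weaker inhibition and lower numbers for stronger inhibition. Compound 1 `COc1ccc(C(=O)O[C@H]2CC(C)=C[C@H](OC(C)=O)[C@@]3(C)[C@@H](OC(C)=O)C[C@@](O)(C(C)C)[C@H]23)cc1` carries two acetoxy groups and an aromatic ester, and in this assay compound 1 gives 2800 nM. Compound 2 `COc1ccc(C(=O)O[C@H]2CC(C)=CC[C@@]3(C)CC[C@@](O)(C(C)C)[C@H]23)cc1` lacks both oxygen substituents on the ring, and in this assay compound 2 gives 17600 nM. Compound 1 thus stands as the lower of the two numbers, and the gap to compound 2 lies beyond the usual scatter.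

Compound 3 `COc1ccc(C(=O)O[C@H]2CC(C)=C[C@H](O)[C@@]3(C)[C@@H](OC(C)=O)C[C@@](O)(C(C)C)[C@H]23)cc1` differs from compound 1 in one place: hydrogen in place of acetyl on an oxygen on a saturated carbon. Among the compounds with values here, no measured pair shows this exact change, so the direction is uncertain; a modest weakening is expected, as the step of a 1.5-fold higher number from compound 1 to compound 3 (0.18 log units; within the scatter) in this assay indicates. Compound 3 is therefore estimated at 4200 nM, with a range from 1500 nM to 12000 nM.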

Compound 3, half-maximal inhibitory concentration: 34400 nM
Estimate against measurement, compound 3: 8.2-fold (0.91 log units) below, outside the stated range (above it).
By their numbers in this assay, from the lowest: compound 1; then compounds 2 and 3 (each within the scatter of the next).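

Changing acetoxy to hydroxy on this saturated carbon gives a 12-fold higher number from compound 1 to compound 3 (1.09 log units; beyond the scatter) in this assay, so losing this acetyl is not a minor edit. The second acetoxy group of the core is the same in both compounds, so this large weakening of inhibition traces to this one position alone. The data available here offer no explanation for the size or the direction of this step.

From the compounds shown here alone, what remains open is whether the acetyl itself is needed or whether another group on this oxygen, such as a methyl ether or a longer butyryl ester, would keep the number close to that of compound 1. The compounds shown also leave open whether changing the second acetoxy group to hydroxy would produce a similar step.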